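Moving the chlorine around the ring of compound 2

This account rests on a few compounds, and the source may have more. Where it says the series, first, only, none or still open, it means among the compounds named here.

In an ADME assay on Vero cells (Chlorocebus sabaeus) for cytotoxicity, read by neutral red uptake, tested at 787 ug/mL (on this read-out lower numbers stand for a stronger effect and higher numbers for a weaker effect at the one concentration tested), compound 1 `O=C1CSC(c2ccc(O)cc2)N1CCN1CCCCC1` gives 57%, and compound 2 `O=C1CSC(c2ccccc2Cl)N1CCN1CCCCC1` gives 38%, the lowest of the two numbers; the step of a number 19 percentage points lower from compound 1 to compound 2 (beyond the scatter) is the only one measured. Compound 3 `O=C1CSC(c2ccc(Cl)cc2)N1CCN1CCCCC1` differs from compound 2 by 4-chlorophenyl in place of 2-chlorophenyl on a saturated ring carbon. For the measured compounds named here, no measured step bears on this change: the one known step replaces 4-hydroxyphenyl with 2-chlorophenyl, whereas here the two structures have the same atoms, joined differently. The step of a number 4 percentage points higher from compound 2 to compound 3 (within the scatter) is therefore expected to stay within the scatter. Compound 3 is estimated at 42%, with a range from 27% to 58%.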

Compound 3, a percentage reported as activity, at one concentration (the size of the read-out at that concentration, not a potency): 15%
The estimate for compound 3 lay 27 percentage points above the measured number, outside the stated range (below it).
By their numbers in this assay, from the lowest: compound 3; then compound 2; then compound 1.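

In this assay, where the chlorine sits on the phenyl ring matters even though the atoms stay the same: 4-chlorophenyl in place of 2-chlorophenyl on the saturated ring carbon gives a number 23 percentage points lower from compound 2 to compound 3 (beyond the scatter). With the attachment held at the same aromatic carbon, chloro in place of hydroxy gives a number 42 percentage points lower from compound 1 to compound 3 (beyond the scatter), so this carbon responds to the group it carries as well. Nothing at hand explains either step. The compounds shown leave open how an amine or a methoxy group on that aromatic carbon would read in this assay.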